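Quinolin-4-yl in place of 2-methylquinolin-8-yl, across an epimer pair

This account rests on a few compounds, and the source may have more. Where it says the series, first, only, none or still open, it means among the compounds named here.

Compound 1 `C=C1CC[C@@H]2[C@](C)(CO)[C@H](O)CC[C@@]2(C)[C@@H]1C/C=C1/C(=O)OC[C@@H]1Oc1cccc2ccc(C)nc12` and compound 2 `C=C1CC[C@@H]2[C@](C)(CO)[C@H](O)CC[C@@]2(C)[C@@H]1C/C=C1/C(=O)OC[C@@H]1Oc1ccnc2ccccc12` are one pair; compound 3 `C=C1CC[C@@H]2[C@](C)(CO)[C@H](O)CC[C@@]2(C)[C@@H]1C/C=C1/C(=O)OC[C@H]1Oc1cccc2ccc(C)nc12` and compound 4 `C=C1CC[C@@H]2[C@](C)(CO)[C@H](O)CC[C@@]2(C)[C@@H]1C/C=C1/C(=O)OC[C@H]1Oc1ccnc2ccccc12` are the other. The cores differ only in configuration: the two compounds have the same atoms and bonds and differ only in configuration as drawn: 1 of 7 stereo elements differ; a stereocentre at a saturated ring carbon is drawn R in compound 1 and S in compound 3.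

In an ADME assay on SNB-19 cells (Homo sapiens) for cytotoxicity, read by MTT assay, with a stated time of 24 h (on this read-out lower numbers stand for higher toxicity in this test and higher numbers for lower toxicity in this test), compound 1 gives only a limit of the assay, > 100000 nM. Compound 2 gives 61200 nM. Compound 3 gives only a limit of the assay, > 100000 nM. The change quinolin-4-yl in place of 2-methylquinolin-8-yl on an oxygen on a saturated carbon gave an at least 1.6-fold lower number from compound 1 to compound 2 (0.21 log units; that floor lies within the scatter). The epimer step that the two limits leave unreadable from compound 1 to compound 3 cannot be read because of the limit of > 100000 nM in this assay, at which 2 of the 3 values shown sit.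

Compound 4 carries the same change on the epimeric core, (quinolin-4-yl in place of 2-methylquinolin-8-yl on an oxygen on a saturated carbon), at the same place. The step in this assay from compound 3 is expected at an at least 1.4-fold lower number from compound 3 to compound 4 (0.15 log units; that floor lies within the scatter), resting on the measured step of an at least 1.6-fold lower number from compound 1 to compound 2 (0.21 log units; that floor lies within the scatter). Compound 4 is therefore expected near 70000 nM, within 30000 nM to 160000 nM.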

Compound 4, half-maximal cytotoxic concentration: 60100 nM
Compound 4: the middle estimate sits 1.2-fold (0.07 log units) above what was measured; the measured number falls inside the stated range.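

In this assay, quinolin-4-yl in place of 2-methylquinolin-8-yl gives an at least 1.6-fold lower number from compound 3 to compound 4 (0.22 log units; that floor lies within the scatter). Both cores yield a floor rather than a size, so the change carries from one core to the other only that far, and equal step sizes are not shown: the same change on two cores in this assay, an at least 1.6-fold lower number (0.21 log units; that floor lies within the scatter) from compound 1 to compound 2 and an at least 1.6-fold lower number (0.22 log units; that floor lies within the scatter) from compound 3 to compound 4; the limit leaves it open whether they differ. With quinolin-4-yl in place, the epimer step reads a 1.0-fold lower number from compound 2 to compound 4 (0.01 log units; within the scatter), so the configuration separates nothing in this pair, while the epimer step with 2-methylquinolin-8-yl cannot be read: the limit of > 100000 nM in this assay, at which 2 of the 4 values shown sit.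

Compound 1 and compound 3 stand only at a limit of the assay, which leaves the size of the change open on either core. Also open, as far as these compounds go, is whether an amine or a carboxylic acid on the quinolin-4-yl group would shift the number on either core.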